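Removing the piperidine hydroxy in a sigma-1 flavone series

A few compounds are considered here, and "the series" means these few. Any claim that something is new, unique, unknown or untested is made for them only; others in the source may bear on it.

Of the compounds shown here, three sharing one core have been measured in an assay on isolated protein (Cavia porcellus) with Sigma non-opioid intracellular receptor 1 (Homo sapiens) as the target, read by radioligand binding; a lower number here means a stronger inhibitor, a higher number a weaker inhibitor. Compound 1 `O=c1cc(-c2ccccc2)oc2ccc(OCCCCCCN3CCC(O)CC3)cc12` gives 100 nM. Compound 2 `O=c1cc(-c2ccccc2Cl)oc2ccc(OCCCCCCN3CCC(O)CC3)cc12` gives 47 nM, and the change in a 2.1-fold lower number from compound 1 to compound 2 (0.33 log units; beyond the scatter) is modest. Compound 3 `O=c1cc(C2CCCC2)oc2ccc(OCCCCCCN3CCC(O)CC3)cc12` gives 51 nM; the steps of a 2.0-fold lower number from compound 1 to compound 3 (0.29 log units; within the scatter) and a 1.1-fold higher number from compound 2 to compound 3 (0.04 log units; within the scatter) both stay within the scatter, so compound 3 sits alongside compound 2 and cannot be separated from either neighbour on these numbers.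

Compound 4 `O=c1cc(C2CCCC2)oc2ccc(OCCCCCCN3CCCCC3)cc12` differs from compound 3 only at the far end of the six-carbon chain: hydrogen in place of hydroxy on a saturated ring carbon. Every measured step in this set concerns the group on the aromatic carbon of the core, not the saturated ring at the chain terminus, so none of them bears on this change. There is no measured evidence for either direction here. With nothing to point one way, the expected outcome is a step that stays within the scatter, a 1.0-fold lower number from compound 3 to compound 4 (0.01 log units; within the scatter), and the expected value for compound 4 in this assay is 50 nM, within a range from 15 nM to 160 nM that reflects the absence of any guiding step.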

Compound 4, half-maximal inhibitory concentration: 26 nM
Beside the measured number, compound 4's estimate is 1.9-fold (0.28 log units) above it; measured number inside the range.
By their numbers in this assay, from the lowest: compounds 4, 2, 3 and 1 (each within the scatter of the next, the first and the last beyond it).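

In this assay, among the compounds shown here, this is the first step in the set taken at the far end of the six-carbon chain rather than on the aromatic carbon of the core, and a 2.0-fold lower number from compound 3 to compound 4 (0.29 log units; within the scatter) shows that 4-hydroxypiperidin-1-yl and piperidin-1-yl cannot be told apart on the cyclopentyl compounds. For the compounds shown here, with hydrogen on this saturated ring carbon, three ring bonds from the ring nitrogen, the hydroxy and its hydrogen-bond donor and acceptor are gone, yet the number stays within the scatter of the one for compound 3, so on these two compounds the hydroxy is not required for a value in this range. No measured finding accounts for the size of this step.

The compounds shown leave open whether the same change would read alike with the phenyl of compound 1 or the 2-chlorophenyl of compound 2 in place of cyclopentyl. They also leave open how a fluoro, a methoxy, an amine or a carboxylic acid on the same ring carbon would compare with hydroxy and hydrogen in this assay.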